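Aryl swap on the triazole: compound 3 expected to stay inactive

A few compounds are considered here, and "the series" means these few. Any claim that something is new, unique, unknown or untested is made for them only; others in the source may bear on it.

In an ADME assay on HUVEC cells (Homo sapiens) for antiproliferative activity, read by MTT assay, with a stated time of 48 h (on this read-out higher numbers stand for weaker inhibition and lower numbers for stronger inhibition), compound 2 `Cc1ccc(-n2nncc2CN2C(=O)C3(C(C#N)=C(N)Oc4c3c3nc5ccccc5nc3c3ccccc43)c3ccccc32)cc1C` gives > 50000 nM, which is a limit of the assay rather than a number. Compound 1 `N#CC1=C(N)Oc2c(c3nc4ccccc4nc3c3ccccc23)C12C(=O)N(Cc1cnnn1-c1cccc(Cl)c1)c1ccccc12` gives > 50000 nM in this assay, likewise a limit. Between them lies a step that the two limits leave unreadable from compound 1 to compound 2, and the limit of > 50000 nM in this assay, at which 2 of the 2 values shown sit, is all the two values show. Compound 3 `N#CC1=C(N)Oc2c(c3nc4ccccc4nc3c3ccccc23)C12C(=O)N(Cc1cnnn1-c1ccc(F)c(Cl)c1)c1ccccc12` differs from compound 2 by 3-chloro-4-fluorophenyl in place of 3,4-dimethylphenyl on an aromatic nitrogen. For the measured compounds named here, the only measured step bearing on this change is the unreadable one, so no step beyond the scatter is expected, and compound 3 is estimated at 50000 nM (range 20000 nM to 200000 nM), most likely again only a limit. The expected step of a number no higher from compound 2 to compound 3 (the limit leaves the size open) is none beyond the scatter.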

Compound 3, half-maximal inhibitory concentration: > 50000 nM
Compound 3: only a limit was reported (the forecaster's own chance of this, stated with the estimate: 85%); the middle value sits exactly at the limit.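

Compound 3 gives > 50000 nM in this assay, again a limit of the assay, so no step can be read from it to compound 1 or compound 2. The compounds shown leave open whether the aryl group on the aromatic nitrogen changes inhibition in this assay at all.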